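The source may hold more compounds than are shown below. What is called first, only, known or untested is meant among the compounds shown, and "the series" means these compounds.

Working notes on the series. Compound 1 `COc1cccc(CNCCCNc2ccnc3cc(Oc4ccccc4)ccc23)c1O`, compound 2 `CCC(CC)c1ccc2c(NCCCNCc3cc(F)ccc3OC)ccnc2c1` and compound 3 `COc1ccc(F)cc1CNCCCNc1ccnc2cc(Oc3ccc(Cl)cc3)ccc12` have been run in a physicochemical assay for solubility, with a stated time of 18 h, at pH 7.4; on this read-out higher numbers stand for higher solubility and lower numbers for lower solubility. Compound 1 gives 14500 nM, compound 2 gives 4200 nM, and compound 3 gives 14500 nM, level with compound 1 and together the two highest numbers; compound 2 stands furthest from compound 3. Among the compounds with values here, the one single-point step recorded is a 3.5-fold higher number from compound 2 to compound 3 (0.54 log units; beyond the scatter). Compound 4 `COc1ccc(F)cc1CNCCCNc1ccnc2cc(Oc3ccccc3)ccc12` differs from compound 3 as follows: hydrogen in place of chloro on an aromatic carbon. Within the data shown here, no recorded step isolates this change. Compound 1 already carries the phenoxy group and gives the same number as compound 3, so in this assay compound 4 is expected to show a 1.0-fold higher number from compound 3 to compound 4 (0.01 log units; within the scatter), with no step beyond the scatter. Compound 4 is estimated at 15000 nM, range 7000 nM to 32000 nM.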

Compound 4, solubility: 14500 nM
The estimate for compound 4 lay 1.0-fold (0.01 log units) above the measured number; the range from low to high includes it.
By their numbers in this assay, from the lowest: compound 2; then compounds 1, 3 and 4 (each within the scatter of the next).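

In this assay the first read isolating this position gives no change at the digits printed from compound 3 to compound 4 (within the scatter) for hydrogen in place of chloro on an aromatic carbon para to a large group. Phenoxy in place of pentan-3-yl gives a 3.5-fold higher number from compound 2 to compound 4 (0.54 log units; beyond the scatter) and so shows a step of the same size without the chloro. With phenoxy in both compounds, 5-fluoro-2-methoxyphenyl in place of 2-hydroxy-3-methoxyphenyl gives no change at the digits printed from compound 1 to compound 4 (within the scatter) on the saturated chain carbon bound to an amine nitrogen. From the compounds shown here alone, what an amine or a carboxylic acid would give at this aromatic carbon stays open. Nothing at hand accounts for these steps.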